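The source may report more compounds than this note shows. Statements on the series, on what has been measured and on what is new or still open speak of the compounds shown alone.

Three compounds have been measured in an assay on HEK293 cells for agonist activity at Toll-like receptor 8 (Homo sapiens), read by spectrophotometry; a higher number here means that more compound is needed for the effect, a lower number that less compound is needed:

Compound 1, `CCCCNc1nc(N)nc(C)c1CCCn1c(C)nc2ccccc21`: 366 nM
Compound 2, `CCCCCc1c(C)nc(N)nc1NCCCC`: 1220 nM
Compound 3, `CCCCNc1nc(N)nc(C)c1CCCN1CCN(C(=O)OC(C)(C)C)CC1`: 300 nM

All three share a core that carries a chain of three saturated carbons, and they differ in what sits at the end of that chain. Compound 2, whose chain ends in a plain saturated tail, has the highest number of the three, so it needs the most compound for the effect. Compound 1 and compound 3, each carrying a ring at the end of the chain, need clearly less, and both of those gaps lie beyond the usual scatter.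

Compound 4, `CCCCNc1nc(N)nc(C)c1CCc1ccccc1`, has not yet been measured. It differs from compound 2 in one place: phenyl in place of propyl on a saturated chain carbon, two bonds along the chain from an aromatic carbon. A flat ring thus takes the place of the saturated tail. Since the two ring-bearing compounds, compound 1 and compound 3, both need less compound than compound 2, a step in the same direction is expected here, of moderate size, a 2.7-fold lower number from compound 2 to compound 4 (0.43 log units; beyond the scatter). Compound 4 is therefore expected to come in near 450 nM, within a range from 150 nM to 1300 nM.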

Compound 4, half-maximal effective concentration: 1190 nM
The estimate for compound 4 lay 2.6-fold (0.42 log units) below the measured number; the measured number falls inside the stated range.
By their numbers in this assay, from the lowest: compounds 3 and 1 (each within the scatter of the next); then compounds 4 and 2 (each within the scatter of the next).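

In this assay, putting phenyl in place of propyl on a saturated chain carbon, two bonds along the chain from an aromatic carbon, gives a 1.0-fold lower number from compound 2 to compound 4 (0.01 log units; within the scatter) and so leaves the read-out effectively unchanged. At this position, then, a six-membered aromatic ring of carbon only and a plain saturated tail cannot be told apart, even though the ring brings more heavy atoms than the propyl it replaces. No supporting measurement is available to explain why the two groups match here.

The compounds shown leave open whether a group of a different kind at this position, such as an amine or a carboxylic acid, would move the number beyond the scatter. They also leave open what a longer chain ending in the same phenyl would do.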